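The source may report more compounds than this note shows. Statements on the series, on what has been measured and on what is new or still open speak of the compounds shown alone.

Compound 1 `O=C1NCCN1c1ccc(S(=O)(=O)Nc2ccc3[nH]ccc3c2)cc1` gives 170 nM.
Compound 2 `Cc1ccc(NS(=O)(=O)c2ccc(N3CCNC3=O)cc2)cc1C` gives 230 nM.
Compound 3 `O=C1NCCN1c1ccc(S(=O)(=O)Nc2ccc(I)cc2)cc1` gives 600 nM.

All three numbers come from a functional assay on MCF7 cells (Homo sapiens) for antiproliferative activity, read by sulforhodamine B assay, with a stated time of 48 h; a lower number here means a stronger inhibitor, a higher number a weaker inhibitor. Compound 3 stands highest of the three measured compounds: the step of a 2.6-fold higher number from compound 2 to compound 3 (0.42 log units; beyond the scatter) is modest but beyond the scatter, and compound 1 lies lower still. Compound 4 `O=C1NCCN1c1ccc(S(=O)(=O)Nc2ccc(Cl)cc2)cc1` differs from compound 3 by chloro in place of iodo on an aromatic carbon. Among the measured pairs, none swaps one halogen for another on this ring; the only step that alters the group on the sulfonamide nitrogen, a 2.6-fold higher number from compound 2 to compound 3 (0.42 log units; beyond the scatter), changes a 3,4-dimethylphenyl into a 4-iodophenyl and is itself modest. On that basis the expected change is small, no change at the digits printed from compound 3 to compound 4 (within the scatter), with no direction that can be told beyond the scatter. Compound 4 is therefore estimated at 600 nM, expected between 250 nM and 1500 nM.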

Compound 4, half-maximal inhibitory concentration: 170 nM
Compound 4: middle estimate off by 3.5-fold (0.55 log units), on the high side; measured number below the stated range.
By their numbers in this assay, from the lowest: compounds 1, 4 and 2 (each within the scatter of the next); then compound 3.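

Swapping only the halogen on this ring is enough to shift the result in this assay, with a 3.5-fold lower number from compound 3 to compound 4 (0.55 log units; beyond the scatter), so this single atom is not interchangeable, even though the step is modest. The 4-chlorophenyl and 3,4-dimethylphenyl groups cannot be told apart here, with a 1.4-fold lower number from compound 2 to compound 4 (0.13 log units; within the scatter), so quite different groups on the sulfonamide nitrogen can give similar numbers. Nothing available explains the gap between chloro and iodo.

On these data alone, whether iodo alone stands apart remains open, as one halogen pair cannot show a trend. As far as these compounds go, how fluoro, bromo, an amine or a carboxylic acid would fare in this place also remains open.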